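Triazole substituent swap in the lactone series

This account rests on a few compounds, and the source may have more. Where it says the series, first, only, none or still open, it means among the compounds named here.

Measured compounds:
compound 1 `O=C1O/C(=C\Cn2cc(-c3ccc(Br)cc3)nn2)C(OCc2ccccc2)=C1OCc1ccccc1`, a functional assay on CFPAC-1 cells (Homo sapiens) for antiproliferative activity, read by MTT assay, with a stated time of 72 h; a higher number here means a weaker inhibitor, a lower number a stronger inhibitor: > 100000 nM, a limit
compound 2 `CCCCc1cn(C[C@H](O)[C@H]2OC(=O)C(OCc3ccccc3)=C2OCc2ccccc2)nn1`, this assay: 73200 nM
compound 3 `COc1ccc(-c2cn(C/C=C3\OC(=O)C(OCc4ccccc4)=C3OCc3ccccc3)nn2)cc1`, this assay: > 100000 nM, a limit

Compound 1 gives only a limit in this assay, > 100000 nM. Compound 3 likewise gives only a limit, > 100000 nM. Among the compounds with values here, compound 2 is therefore the one compound of the three with a number, 73200 nM, and it stands alone in that respect. The other two values sit at the limit of > 100000 nM in this assay, at which 2 of the 3 values shown sit.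

Within the data shown here, the one measured step, a step that the two limits leave unreadable from compound 1 to compound 3, runs between two limits and its size cannot be read. It concerns the group on the phenyl ring, not the triazole, and so gives no guide to the change now in question.

Compound 4 `C[Si](C)(C)c1cn(C[C@H](O)[C@H]2OC(=O)C(OCc3ccccc3)=C2OCc2ccccc2)nn1` differs from compound 2 in one place: a group of 4 heavy atoms (3 carbon, 1 silicon; no ring) in place of a group of 4 heavy atoms (4 carbon; no ring), on an aromatic carbon. Among the measured compounds shown here, no measured step touches this position, so no direction beyond the scatter is expected; the step from compound 2 is estimated as a 1.1-fold higher number from compound 2 to compound 4 (0.04 log units; within the scatter). Compound 4 is expected to give about 80000 nM in this assay, within 30000 nM to 200000 nM, with a fair chance that only a limit is reported.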

Compound 4, half-maximal inhibitory concentration: 52600 nM
Compound 4: middle estimate off by 1.5-fold (0.18 log units), on the high side; measured number inside the range.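

At this position, on an aromatic carbon of the five-membered aromatic ring with 3 nitrogen, the group of 4 heavy atoms (3 carbon, 1 silicon) in place of butyl gives a 1.4-fold lower number from compound 2 to compound 4 (0.14 log units; within the scatter) in this assay. Within the data shown here, this is the first readable step, and it shows that compound 2 and compound 4 cannot be told apart in this assay, so this exchange of one carbon for silicon in a group without a ring leaves the read-out unchanged within the usual scatter. Compound 4 also gives a number rather than a limit, and the step between compound 1 and compound 3 still cannot be read: the limit of > 100000 nM in this assay, at which 2 of the 4 values shown sit.

Only butyl and this silicon-bearing group are shown at this position with the hydroxyl-bearing side chain, so it remains open whether a longer chain such as decyl, an amine or a carboxylic acid there would give a step beyond the scatter. Compound 1 and compound 3 differ from compound 2 in more than one place, which leaves open what a substituted phenyl on the triazole would do alongside that side chain.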